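The compounds below may be only part of what the source reports. "The series", "measured", "known", "first", "only" and "open" are said of these compounds alone.

Measured in a functional assay on MCF7 cells (Homo sapiens) for antiproliferative activity; on this read-out lower numbers stand for stronger inhibition and higher numbers for weaker inhibition:
- compound 1 `CC(C)=CCc1cc(C(=O)Nc2cc3ccc(OCC4CCN(C)C4)c(C)c3oc2=O)ccc1O`: 1550 nM
- compound 2 `CC(C)=CCc1cc(C(=O)Nc2cc3ccc(OCCCN(C(C)C)C(C)C)c(C)c3oc2=O)ccc1O`: 1310 nM
- compound 3 `CC(C)=CCc1cc(C(=O)Nc2cc3ccc(OCCCN[C@H](C)c4ccccc4)c(C)c3oc2=O)ccc1O`: 1450 nM

At 1450 nM, compound 3 stands level with the other two, and the three values lie within the scatter of one another. The next structure, compound 4 `CC(C)=CCc1cc(C(=O)Nc2cc3ccc(OCCCNC(C)(C)c4ccccc4)c(C)c3oc2=O)ccc1O`, carries 1-methyl-1-phenylethyl in place of 1-phenylethyl on an amine nitrogen. Among the compounds with values here, no measured step makes this exact change. The closest evidence comes from changes to the same side chain: a 1.1-fold higher number from compound 2 to compound 3 (0.04 log units; within the scatter), and a 1.1-fold lower number from compound 1 to compound 3 (0.03 log units; within the scatter). Both stay within the scatter, so no shift beyond it is expected, although the data cannot exclude one for this new group. The estimated step is a 1.0-fold lower number from compound 3 to compound 4 (0.02 log units; within the scatter). Compound 4 is expected at about 1400 nM, with an estimated range of 800 nM to 2400 nM.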

Compound 4, half-maximal inhibitory concentration: 1070 nM
Beside the measured number, compound 4's estimate is 1.3-fold (0.12 log units) above it, and the stated range covers the measured number.
By their numbers in this assay, from the lowest: compounds 4, 2, 3 and 1 (each within the scatter of the next).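

In this assay, replacing 1-phenylethyl with 1-methyl-1-phenylethyl on the amine nitrogen removes the defined stereocentre and gives a 1.4-fold lower number from compound 3 to compound 4 (0.13 log units; within the scatter) and so shows that this stereocentre is not required for a value in this range. Compound 4 also remains level with the other side chains, with a 1.2-fold lower number from compound 2 to compound 4 (0.09 log units; within the scatter) and a 1.4-fold lower number from compound 1 to compound 4 (0.16 log units; within the scatter) and thus no side chain shown moves the number beyond the scatter. As far as these compounds go, whether a cyclohexyl group in place of the phenyl ring, or a longer chain leading to the amine nitrogen, would do so remains open. No supporting evidence bears on this result.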